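The compounds below may be only part of what the source reports. "The series", "measured", "known", "first", "only" and "open" are said of these compounds alone.

Measured so far in an ADME assay on a cell-free system (plasma, Rattus norvegicus) for protein binding:

- compound 1 `O=C(O)c1cn(Cc2ccc(-n3cccn3)cc2)c2cccc(F)c2c1=O`: 88.4%
- compound 2 `Cc1ccn(-c2ccc(Cn3cc(C(=O)O)c(=O)c4c(F)cccc43)cc2)n1`: 94.3%
- compound 3 `O=C(O)c1cn(Cc2ccc(-n3ccc4cccnc43)cc2)c2cccc(F)c2c1=O`: 99%

Of these three, compound 2 holds the middle place on the unbound fraction. Two steps frame that place: a 2.0-fold lower unbound fraction from compound 1 to compound 2 (0.31 log units; beyond the scatter), and a 5.7-fold lower unbound fraction from compound 2 to compound 3 (0.76 log units; beyond the scatter).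

Compound 4 `O=C(O)c1cn(Cc2ccc(-n3ccc4cnccc43)cc2)c2cccc(F)c2c1=O` keeps the shared core and differs from compound 2 in a single group: a group of 9 heavy atoms (7 carbon, 2 nitrogen; one five-membered aromatic ring with 1 hetero atom, one six-membered aromatic ring with 1 hetero atom) in place of a group of 6 heavy atoms (4 carbon, 2 nitrogen; one five-membered aromatic ring with 2 hetero atoms), on an aromatic carbon. For the measured compounds named here, the entering group has the same counts as the group carried by compound 3, so the closest precedent is a 5.7-fold lower unbound fraction from compound 2 to compound 3 (0.76 log units; beyond the scatter). The related exchange a 12-fold lower unbound fraction from compound 1 to compound 3 (1.06 log units; beyond the scatter) points the same way, although it starts from the compound without the methyl group and is larger. Both steps lower the unbound fraction, and both lie beyond the scatter. However, no measurement yet separates the group in compound 3 from the different arrangement of the same ring types in compound 4, so the precedent is only a guide. A modest move in the same direction is therefore expected, somewhat smaller than the precedent. The expected step is a 2.3-fold lower unbound fraction from compound 2 to compound 4 (0.36 log units; beyond the scatter). For compound 4 the estimated value in this assay is 97.5%, with an expected range from 94.5% to 99.2%.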

Compound 4, plasma protein binding: 96.9%
Compound 4: middle estimate off by 1.2-fold (0.09 log units) (unbound fraction), on the low side; the range from low to high includes it.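

Compound 3 alone could not show whether the exchange depended on the larger group as such, but compound 4, whose entering group has the same atom counts and ring types, shows that in this assay the arrangement of those rings matters at this aromatic carbon, para to a large group (a 3.1-fold higher unbound fraction from compound 3 to compound 4 (0.49 log units; beyond the scatter)). The count of heavy atoms therefore does not settle the outcome: the exchange of the 3-methyl-1H-pyrazol-1-yl group that went beyond the scatter with compound 3 leaves compound 4 not separable from compound 2 (a 1.8-fold lower unbound fraction from compound 2 to compound 4 (0.26 log units; within the scatter)). Compound 4 is still set apart from compound 1, which carries the smaller group without the methyl (a 3.7-fold lower unbound fraction from compound 1 to compound 4 (0.57 log units; beyond the scatter)), so among these compounds it differs clearly from compound 1 and compound 3 but not from compound 2.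

Nothing available explains why the two arrangements of the same ring types part in this way. Going by these compounds, it also remains open how this assay would respond at this position to a plain phenyl ring, a morpholine or a dimethylamino group.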